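This account rests on a few compounds, and the source may have more. Where it says the series, first, only, none or still open, it means among the compounds named here.

Compound 2 `CCOc1ccccc1-n1nncc1CN1C(=O)C2(C(C#N)=C(N)Oc3c(N)cc4nc5ccccc5nc4c32)c2ccccc21` stands in an ADME assay on L02 cells (Homo sapiens) for antiproliferative activity, read by MTT assay, with a stated time of 48 h (on this read-out lower numbers stand for stronger inhibition and higher numbers for weaker inhibition), only at a limit: compound 2 gives > 50000 nM. Compound 1 `COc1ccc(-n2nncc2CN2C(=O)C3(C(C#N)=C(N)Oc4c(N)cc5nc6ccccc6nc5c43)c3ccccc32)cc1` likewise reaches only a limit, since compound 1 gives > 50000 nM. Both values sit where the limit of > 50000 nM in this assay, at which 2 of the 2 values shown sit, places them. Going by the values given here, the single measured step, a step that the two limits leave unreadable from compound 1 to compound 2, is therefore unreadable in size and direction. Compound 3 `N#CC1=C(N)Oc2c(N)cc3nc4ccccc4nc3c2C12C(=O)N(Cc1cnnn1-c1ccc(F)c(Cl)c1)c1ccccc12` differs from compound 2 by 3-chloro-4-fluorophenyl in place of 2-ethoxyphenyl on an aromatic nitrogen. Among the compounds with values here, no measured step bears on this exchange, and the one step recorded gives no readable size, so nothing beyond the scatter can be expected in this assay in either direction; the expectation is that compound 3 remains at the same limit. The step of a number no higher from compound 2 to compound 3 (the limit leaves the size open) is thus expected to be flat. For compound 3 the estimate in this assay is 50000 nM, with a range from 20000 nM to 100000 nM.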

Compound 3, half-maximal inhibitory concentration: > 50000 nM
Compound 3 gave a limit, no number (the forecaster's own chance of this, stated with the estimate: 75%); the middle value lies on the limit itself.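

Going by these compounds alone, no step among compound 1, compound 2 and compound 3 can be read in this assay, since each result is a limit and not a number: the limit of > 50000 nM in this assay, at which 3 of the 3 values shown sit. The compounds shown leave open the size and direction of each exchange on the aromatic nitrogen in this assay.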